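The compounds below may be only part of what the source reports. "The series", "measured", "known", "first", "only" and "open" are said of these compounds alone.

Among the measured compounds shown here, in an ADME assay on MT4 cells (Homo sapiens) for cytotoxicity (on this read-out higher numbers stand for lower toxicity in this test and lower numbers for higher toxicity in this test), compound 1 (`Fc1ccc(NC(=S)Nc2cccc(C(F)(F)F)c2)cc1`) gives 31000 nM and compound 2 (`FC(F)(F)c1cccc(NC(=S)Nc2cccc(Br)c2)c1`) gives 9200 nM, so compound 2 holds the lower of the two numbers so far. Compound 3 (`FC(F)(F)c1cccc(NC(=S)NCc2ccco2)c1`) has (furan-2-yl)methyl in place of 3-bromophenyl on an amide-type nitrogen. For the measured compounds named here, one measured step bears on this change: a 3.4-fold lower number from compound 1 to compound 2 (0.53 log units; beyond the scatter), modest but beyond the scatter, with 3-bromophenyl in place of 4-fluorophenyl on an amide-type nitrogen. That single step links 3-bromophenyl with the lower number, but the entering group in compound 3 is unlike either aromatic group measured so far. A modest rise in this assay is therefore expected, of about the same size as that step and with wide uncertainty. The estimated change is a 3.3-fold higher number from compound 2 to compound 3 (0.51 log units; beyond the scatter). For compound 3 the estimated value is 30000 nM, with an expected range of 11000 nM to 90000 nM.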

Compound 3, half-maximal cytotoxic concentration: 43000 nM
Estimate against measurement, compound 3: 1.4-fold (0.16 log units) below, and the stated range covers the measured number.
By their numbers in this assay, from the lowest: compound 2; then compounds 1 and 3 (each within the scatter of the next).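

In this assay the change of 3-bromophenyl to (furan-2-yl)methyl on the amide-type nitrogen gives a 4.7-fold higher number from compound 2 to compound 3 (0.67 log units; beyond the scatter) as a modest step, so this position accepts a five-membered aromatic ring with 1 hetero atom without a fall in the number. The other comparison, a 1.4-fold higher number from compound 1 to compound 3 (0.14 log units; within the scatter), lies within the scatter, so (furan-2-yl)methyl and 4-fluorophenyl cannot be told apart here, and of the three groups only 3-bromophenyl stands apart, with the lower number. Nothing available gives a reason for either step.

As far as these compounds go, whether the step belongs to the furan ring, the methyl link or the loss of bromine stays open. A benzyl or a (thiophen-2-yl)methyl group on the same nitrogen would help to separate these, and the trifluoromethyl side of the core remains untested in the compounds shown.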